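A few compounds are considered here, and "the series" means these few. Any claim that something is new, unique, unknown or untested is made for them only; others in the source may bear on it.

For the measured compounds named here, compound 1 `COc1ccc(-c2cn(C[C@H](O)[C@H]3OC(=O)C(OCc4ccccc4)=C3OCc3ccccc3)nn2)cc1` is the only compound in this set with a numerical result: in a functional assay on A549 cells (Homo sapiens) for antiproliferative activity, read by MTT assay, with a stated time of 72 h (on this read-out lower numbers stand for stronger inhibition and higher numbers for weaker inhibition), compound 1 gives 28300 nM. Compound 2 `CC(C)(C)OC(=O)N1CCN(C(=S)SCc2cn(C[C@H](O)[C@H]3OC(=O)C(OCc4ccccc4)=C3OCc3ccccc3)nn2)CC1` reaches only a limit of the assay: in this assay compound 2 gives > 100000 nM, so no number is known for it. Compound 3 `CCCCc1cn(C[C@H](O)[C@H]2OC(=O)C(OCc3ccccc3)=C2OCc2ccccc2)nn1` has not yet been measured. It differs from compound 1 in one place: butyl in place of 4-methoxyphenyl on an aromatic carbon. Going by the values given here, no pair of measured compounds shows what a change of this kind does here, so the size of the step cannot be read directly from the data. Since one of the two values recorded sits at the limit of > 100000 nM in this assay, at which 1 of the 2 values shown sits, a cautious expectation is a small step toward weaker inhibition, or none beyond the usual scatter. The expected step is a 1.6-fold higher number from compound 1 to compound 3 (0.20 log units; within the scatter). Compound 3 is therefore expected to give an estimated 45000 nM in this assay, within a range of 15000 nM to 100000 nM.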

Compound 3, half-maximal inhibitory concentration: 28600 nM
For compound 3 the middle estimate is 1.6-fold (0.20 log units) above the measured one; low and high end bracket the measured number.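

In this assay, butyl in place of 4-methoxyphenyl on this aromatic carbon comes with a 1.0-fold higher number from compound 1 to compound 3 (0.00 log units; within the scatter). The six-membered aromatic ring and the hydrogen-bond acceptor that leave with 4-methoxyphenyl are therefore not required to hold this level of activity, and a chain without a ring does just as well here, which compound 1 alone could not show. Compound 2 gives no number, only a limit of the assay, so steps to it cannot be read: the limit of > 100000 nM in this assay, at which 1 of the 3 values shown sits.

For the compounds shown here, whether any group at this position can bring the number clearly lower stays open, since these two numbers show only one change with no effect beyond the scatter. On these data alone, what an octyl chain, an amine or a carboxylic acid would do in this place is also open.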